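Removing a Methyl Next on the Alkyne Series

This account rests on a few compounds, and the source may have more. Where it says the series, first, only, none or still open, it means among the compounds named here.

Of the compounds shown here, three sharing an alkyne-linked two-ring core have been measured in an in vitro functional assay on 1321-N1 cells for agonist activity at Free fatty acid receptor 1 (Homo sapiens), read by fluorescence; a lower number here means that less compound is needed, a higher number that more compound is needed for the effect. Compound 1 `Cc1cccc(C#Cc2ccc(CCC(=O)O)cc2)c1C` gives 87.1 nM in this assay. Compound 2 `Cc1cccc(C#Cc2ccc(CCC(=O)O)cc2)c1` gives 43.7 nM in this assay, and the step of a 2.0-fold lower number from compound 1 to compound 2 (0.30 log units; within the scatter) lies within the scatter. Compound 3 `Cc1cccc(C#Cc2ccc(OCC(=O)O)cc2)c1` gives 513 nM in this assay, the highest of the three numbers; the step of a 12-fold higher number from compound 2 to compound 3 (1.07 log units; beyond the scatter) is large and beyond the scatter, the outcome of swapping the side chain that carries the acid.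

Compound 4 `O=C(O)COc1ccc(C#Cc2ccccc2)cc1` differs from compound 3 by hydrogen in place of methyl on an aromatic carbon. For the measured compounds named here, the one measured step that bears on this change is the step from compound 1 to compound 2, where a methyl was likewise replaced by hydrogen on an aromatic carbon and the result stayed within the scatter. On that basis no step beyond the scatter is expected in this assay for compound 4, though a modest drift toward a lower number cannot be excluded because of a 2.0-fold lower number from compound 1 to compound 2 (0.30 log units; within the scatter).

Compound 4 is therefore expected to give about 400 nM in this assay, with a plausible range from 150 nM to 1200 nM, which corresponds to an expected step of a 1.3-fold lower number from compound 3 to compound 4 (0.11 log units; within the scatter).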

Compound 4, half-maximal effective concentration: 1260 nM
For compound 4 the middle estimate is 3.2-fold (0.50 log units) below the measured one; the measured number lies above the stated range.
By their numbers in this assay, from the lowest: compounds 2 and 1 (each within the scatter of the next); then compound 3; then compound 4.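

In this assay, taking the methyl off the aromatic carbon meta to a large group is not a neutral edit: it gives a 2.5-fold higher number from compound 3 to compound 4 (0.39 log units; beyond the scatter), so more compound is needed once this methyl is gone. The earlier compounds shown here showed hydrogen in place of methyl only as a step within the scatter, and the new result shows that this change has no single size across the series: the same change on two cores in this assay, a 2.0-fold lower number (0.30 log units; within the scatter) from compound 1 to compound 2 and a 2.5-fold higher number (0.39 log units; beyond the scatter) from compound 3 to compound 4, 4.9-fold (0.69 log units) apart, beyond the scatter of two such steps The two steps also differ in more than their direction, since compound 2 still carries a methyl on that ring while compound 4 carries none, and the acid sits on a 2-carboxyethyl chain in compound 2 but on a carboxymethoxy chain in compound 4.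

The compounds shown leave open which of these two differences separates the steps, and a compound with the 2-carboxyethyl chain and no methyl on the other ring would help to tell them apart. They also leave open whether the methyl itself matters at this place, or whether another group there, such as an ethyl, a methoxy or a chlorine, would serve as well.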